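The compounds below may be only part of what the source reports. "The series", "measured", "known", "first", "only" and "open" are said of these compounds alone.

Measured compounds in an ADME assay on Huh-7 cells (Homo sapiens) for cytotoxicity; a lower number here means that less compound is tolerated, a higher number that more compound is tolerated:
Compound 1 `COc1ccc(C(=O)NC(=S)N2CCc3c(OCCCCCOc4ccc(Cl)cc4)cccc32)cc1` gives 34400 nM.
Compound 2 `CC(C)(C)c1ccc(C(=O)NC(=S)N2CCc3c(OCCCCCOc4ccc(Cl)cc4)cccc32)cc1` gives only the assay limit, > 50000 nM.
Compound 3 `CCCC(=O)NC(=S)N1CCc2c(OCCCCCOc3ccc(Cl)cc3)cccc21` likewise gives only the assay limit, > 50000 nM.

Compound 3 thus stands at the upper limit of this assay, a position it shares with one further value (the limit of > 50000 nM in this assay, at which 2 of the 3 values shown sit). Compound 4 `O=C(NC(=S)N1CCc2c(OCCCCCOc3ccc(Cl)cc3)cccc21)c1ccno1` differs from compound 3 by 1,2-oxazol-5-yl in place of propyl on a carbonyl carbon. The nearest comparison is the exchange at the same carbonyl carbon, an at least 1.4-fold higher number from compound 1 to compound 3 (0.16 log units; that floor lies within the scatter), whose floor lies within the scatter; the step that the two limits leave unreadable from compound 2 to compound 3 cannot be read. With two of the three values sitting at the limit (the limit of > 50000 nM in this assay, at which 2 of the 3 values shown sit), little room remains for a readable change, and compound 4 is expected to stay at or near the limit. For compound 4 the estimate is 45000 nM, with a range of 20000 nM to 100000 nM. This corresponds to an expected step of an at least 1.1-fold lower number from compound 3 to compound 4 (0.04 log units; that floor lies within the scatter).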

Compound 4, half-maximal cytotoxic concentration: 37100 nM
Beside the measured number, compound 4's estimate is 1.2-fold (0.08 log units) above it; low and high end bracket the measured number.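

In this assay, an aromatic ring with hetero atoms on the carbonyl carbon gives a number rather than a limit, and it does not separate from the 4-methoxyphenyl group: a 1.1-fold higher number from compound 1 to compound 4 (0.03 log units; within the scatter). The floors of the other two steps, an at least 1.3-fold lower number from compound 3 to compound 4 (0.12 log units; that floor lies within the scatter) and an at least 1.3-fold lower number from compound 2 to compound 4 (0.12 log units; that floor lies within the scatter), do not separate 1,2-oxazol-5-yl from propyl or 4-(tert-butyl)phenyl. All four groups on this carbonyl carbon leave the series close to the upper limit: the limit of > 50000 nM in this assay, at which 2 of the 4 values shown sit.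

From the compounds shown here alone, whether a group carrying an amine or a carboxylic acid on this carbonyl carbon would give a step beyond the scatter stays open.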